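The source may report more compounds than this note shows. Statements on the series, on what has been measured and on what is new or still open speak of the compounds shown alone.

Going by the values given here, in a functional assay on KB cells (Homo sapiens) for inhibition (a lower number here means a stronger inhibitor, a higher number a weaker inhibitor), compound 3 `OCCOCn1c(SCc2ccccc2)nc2cc(Cl)c(Cl)cc21` gives 55000 nM, the only plain number among the three results at hand. Compound 1 `OCCOCn1c(Cl)nc2cc(Cl)c(Cl)cc21` reaches only the limit > 320000 nM. Compound 2 `CNc1nc2cc(Cl)c(Cl)cc2n1COCCO` likewise reaches only the limit > 100000 nM. Compound 4 `OCCOCn1cnc2cc(Cl)c(Cl)cc21` has not yet been measured; it differs from compound 3 by hydrogen in place of benzylsulfanyl on an aromatic carbon. Among the compounds with values here, two measured steps bear on this change, each ending at a benzylsulfanyl group: an at least 5.8-fold lower number from compound 1 to compound 3 (0.76 log units; beyond the scatter), and an at least 1.8-fold lower number from compound 2 to compound 3 (0.25 log units; that floor lies within the scatter). Going by these compounds, both of these steps start from a limit, namely the limit of > 320000 nM in this assay, at which 1 of the 3 values shown sits, and (the limit of > 100000 nM in this assay, at which 1 of the 3 values shown sits), so their true size stays open, but both point the same way: the compound carrying the benzylsulfanyl group shows the lower number, and taking that group away is expected to push the number back up. A step of a 5.5-fold higher number from compound 3 to compound 4 (0.74 log units; beyond the scatter) is therefore expected. Compound 4 is expected to give about 300000 nM, within a range from 100000 nM to 1000000 nM, and it is quite possible that only a limit is reported.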

Compound 4, half-maximal inhibitory concentration: > 100000 nM
Compound 4 ended at the assay's limit (the forecaster's own chance of this, stated with the estimate: 70%); the middle value is on the limit's open side.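

On this aromatic carbon between two ring nitrogen atoms, the benzylsulfanyl group has so far been compared only with chloro and methylamino, and replacing it with plain hydrogen in this assay gives an at least 1.8-fold higher number from compound 3 to compound 4 (0.25 log units; that floor lies within the scatter). Compound 4 stops at a limit: the limit of > 100000 nM in this assay, at which 2 of the 4 values shown sit. Compound 3 thus remains the only one of the four with a plain number, while the steps from compound 1 and from compound 2 to compound 4 join limit to limit and cannot be read.

Going by these compounds, how far the true value of compound 4 lies past its limit stays open, and with it the real size of the change. Also open, on these data alone, is whether a methylsulfanyl or a benzyloxy group on this carbon would give a plain number, which would help separate the part played by the sulfur from that of the benzene ring.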